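The compounds below may be only part of what the source reports. "The series", "measured", "known", "first", "only" and "open" are said of these compounds alone.

Measured so far:
compound 1 `Cc1cc(C)c(NC(=O)N(Cc2cccc(-c3cc[nH]n3)c2)C2CCCCC2)c(C)c1` gives 0.12 mg/kg in a functional assay on a cell-free system (plasma) with sterol O-acyltransferase, Soat (Rattus norvegicus) as the target; on this read-out higher numbers stand for an effect only at larger amounts of compound and lower numbers for an effect already at smaller amounts
compound 2 `Cc1cc(C)c(NC(=O)N(Cc2cccc(-c3cc[nH]n3)c2)C2CCCCCC2)c(C)c1` gives 0.097 mg/kg in this assay

Within the data shown here, compound 2 stands at the lowest of the two numbers, and its only neighbour is compound 1, which differs by a 1.2-fold lower number from compound 1 to compound 2 (0.09 log units; within the scatter). Compound 3 `Cc1cc(C)c(NC(=O)N(Cc2cccc(-c3cnn(C)c3)c2)C2CCCCCC2)c(C)c1` has not been measured; it carries 1-methyl-1H-pyrazol-4-yl in place of 1H-pyrazol-3-yl on an aromatic carbon. Among the measured compounds shown here, the one measured step, between compound 1 and compound 2, touches only the saturated ring on the urea nitrogen and says nothing about the aromatic five-membered ring, so no measured step bears on this change. Without a guide, the expectation rests on the swap itself: a group with one hydrogen-bond donor leaves and one with two acceptors and no donor enters, a change large enough that a shift beyond the scatter cannot be ruled out in either direction. A modest rise, so a weaker effect, is the expected middle, with a 2.1-fold higher number from compound 2 to compound 3 (0.31 log units; beyond the scatter). Compound 3 is therefore estimated at 0.2 mg/kg, with a range from 0.05 mg/kg to 0.8 mg/kg.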

Compound 3, dose for half-maximal effect: < 1 mg/kg
Compound 3 gave a limit, no number; the forecaster's own chance of this, stated with the estimate: 10%; the middle value lies beyond the limit too.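

In this assay compound 3 gives < 1 mg/kg, which is a limit and not a number. The step between compound 2 and compound 3 cannot be read from it. The compounds shown leave open how large the effect of replacing 1H-pyrazol-3-yl with 1-methyl-1H-pyrazol-4-yl is, and in which direction it goes.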